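Benzo-fused amino alcohols at the sigma non-opioid intracellular receptor 1

The source may hold more compounds than are shown below. What is called first, only, known or untested is meant among the compounds shown, and "the series" means these compounds.

Measured compounds:
compound 1 `OC1CC(NCCCCc2ccccc2)CCc2ccccc21` 140 nM
compound 2 `CN(CCCCc1ccccc1)C1CCc2ccccc2C(O)C1` 33 nM

In an assay on cell membranes for displacement of a labelled ligand from Sigma non-opioid intracellular receptor 1 (Cavia porcellus), read by scintillation counting, with a stated time of 120 min (on this read-out lower numbers stand for stronger inhibition and higher numbers for weaker inhibition), compound 2 gives the lowest of the two numbers shown; the nearest is compound 1, and the step of a 4.2-fold lower number from compound 1 to compound 2 (0.63 log units; beyond the scatter) lies beyond the scatter. Compound 3 `CN(CCCc1ccccc1)C1CCc2ccccc2C(O)C1` is not yet measured. It differs from compound 2 by phenyl in place of benzyl on a saturated chain carbon, three bonds along the chain from an amine nitrogen; the same difference, cut one bond further out, reads phenethyl to benzyl.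

For the measured compounds named here, the only measured step, from compound 1 to compound 2, concerns the amine nitrogen and not the chain that carries the aromatic ring, so no step speaks to the change at hand. Nothing is known here about shortening that chain by one carbon. Compound 3 is therefore expected to stay close to compound 2, with a step of about a 1.2-fold higher number from compound 2 to compound 3 (0.08 log units; within the scatter) that is within the scatter; the estimate for compound 3 in this assay is 40 nM, with a range from 12 nM to 130 nM.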

Compound 3, inhibition constant: 39 nM
Estimate against measurement, compound 3: 1.0-fold (0.01 log units) above, within the range that was stated.
By their numbers in this assay, from the lowest: compounds 2 and 3 (each within the scatter of the next); then compound 1.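

In this assay, for the compounds shown here, the first reading on the chain that carries the aromatic ring is a 1.2-fold higher number from compound 2 to compound 3 (0.07 log units; within the scatter), so the two compounds cannot be told apart. With the methyl on the amine nitrogen, phenyl in place of benzyl at this chain carbon, three bonds along the chain from an amine nitrogen, therefore leaves the reading within the scatter, whereas the earlier step spoke only to the amine nitrogen. Nothing at hand offers an explanation for this result.

The chain change is read only with the methyl on the amine nitrogen, which leaves open how it reads on the amine of compound 1, where hydrogen stands in place of that methyl. Also open, from the compounds shown here alone, are a chain longer than that of compound 2 and a pyridyl in place of the terminal phenyl.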